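The source may report more compounds than this note shows. Statements on the series, on what has been measured and on what is new or still open speak of the compounds shown alone.

Measured so far:
compound 1 `CC(C)c1cnc(C(=O)/C=C/c2ccccc2O)cn1` — 167000 nM
compound 2 `CC(C)Cc1cnc(C(=O)/C=C/c2ccccc2O)cn1` — 144000 nM

Both numbers come from a functional assay on the whole organism for inhibition, with Spinacia oleracea as the target, read by spectrophotometry, with a stated time of 4 h; a lower number here means a stronger inhibitor, a higher number a weaker inhibitor. Compound 2 stands with the lowest of the two numbers; its nearest neighbour is compound 1, and the step of a 1.2-fold lower number from compound 1 to compound 2 (0.06 log units; within the scatter) lies within the scatter, so the two compounds cannot be told apart on these numbers. Compound 3 `CCCc1cnc(C(=O)/C=C/c2ccccc2O)cn1` has not yet been measured in this assay. It differs from compound 2 by hydrogen in place of methyl on a saturated chain carbon bound to two saturated chain carbons. Among the measured compounds shown here, only one measured step bears on this change: the step of a 1.2-fold lower number from compound 1 to compound 2 (0.06 log units; within the scatter) altered the same short chain on the shared core, swapping isopropyl for isobutyl, and it stayed within the scatter. Shortening isobutyl to propyl is a change of similar kind and size, so the expectation is for no step beyond the scatter in this assay in either direction, which is expressed as a 1.0-fold higher number from compound 2 to compound 3 (0.02 log units; within the scatter). Compound 3 is therefore estimated at 150000 nM in this assay, with an expected range from 75000 nM to 300000 nM.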

Compound 3, half-maximal inhibitory concentration: 187000 nM
Compound 3: middle estimate off by 1.2-fold (0.10 log units), on the low side, within the range that was stated.
By their numbers in this assay, from the lowest: compounds 2, 1 and 3 (each within the scatter of the next).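

In this assay, among the compounds shown here, taking the methyl off the saturated chain carbon, which turns isobutyl into propyl, gives a 1.3-fold higher number from compound 2 to compound 3 (0.11 log units; within the scatter) and so produces no step that can be read. Replacing isopropyl with propyl on the aromatic carbon gives a 1.1-fold higher number from compound 1 to compound 3 (0.05 log units; within the scatter), which also stays within the scatter. Where the earlier compounds offered a single comparison, isopropyl, isobutyl and propyl now form a set of three chains on the shared core that these numbers cannot separate, and no further evidence bears on this result.

The compounds shown leave open whether a longer chain such as hexyl, or a quite different group such as an amine or a carboxylic acid on the same aromatic carbon, would move the number beyond the scatter. Since only this one chain varies here, they also say nothing about how changes elsewhere on the shared core would read in this assay.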